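Swapping the aryl group: three compounds, one unchanged read-out

A few compounds are considered here, and "the series" means these few. Any claim that something is new, unique, unknown or untested is made for them only; others in the source may bear on it.

Compound 1 `COc1cc(OC)c(OC)cc1/C=C/COC(=O)/C=C/c1ccc(OC)c(OC)c1` gives 100% in a functional assay on the whole organism (strain Kunming) with Mus musculus as the target, with a stated time of 0.5 h, at a dose of 300 mg/kg by the intraperitoneal route; on this read-out higher numbers stand for a weaker effect at the one dose given and lower numbers for a stronger effect.
Compound 2 `COc1cc(OC)c(OC)cc1/C=C/COC(=O)/C=C/c1ccccc1C(F)(F)F` gives 100% in this assay.
Compound 3 `COc1cc(OC)c(OC)cc1/C=C/COC(=O)/C=C/c1ccc(Br)cc1` gives 100% in this assay.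

Compound 1 stands level with compounds 2 and 3; its nearest neighbour on the numbers is compound 2 and its furthest is compound 3, and neither gap is beyond the scatter. Compound 4 `COc1cc(OC)c(OC)cc1/C=C/COC(=O)/C=C/c1ccccc1Cl` differs from compound 1 in one place: 2-chlorophenyl in place of 3,4-dimethoxyphenyl on a double-bonded chain carbon bound to a double-bonded chain carbon. Three measured steps change the same aryl group at the same place: no change at the digits printed from compound 1 to compound 2 (within the scatter), no change at the digits printed from compound 1 to compound 3 (within the scatter) and no change at the digits printed from compound 2 to compound 3 (within the scatter). Each was flat. Because no change at the digits printed from compound 1 to compound 2 (within the scatter) and no change at the digits printed from compound 1 to compound 3 (within the scatter) were both flat, no step beyond the scatter is expected here either, so the expected step is no change at the digits printed from compound 1 to compound 4 (within the scatter). Compound 4 is therefore estimated at 100%, with a range of 90% to 100%.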

Compound 4, a percentage reported as activity, at one dose (the size of the read-out at that dose, not a potency): 100%
The estimate for compound 4 equals the measured number at the digits printed; low and high end bracket the measured number.
By their numbers in this assay, from the lowest: compounds 1, 2, 3 and 4 (each within the scatter of the next).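

In this assay, the step is no change at the digits printed from compound 1 to compound 4 (within the scatter) when 2-chlorophenyl, with 7 heavy atoms and 0 hydrogen-bond acceptors, replaces 3,4-dimethoxyphenyl, with 10 heavy atoms and 2 hydrogen-bond acceptors. The other two comparisons are also flat, with no change at the digits printed from compound 3 to compound 4 (within the scatter) for 2-chlorophenyl in place of 4-bromophenyl and no change at the digits printed from compound 2 to compound 4 (within the scatter) for chloro in place of trifluoromethyl on an aromatic carbon. Nothing available explains why the read-out stays level.

As far as these compounds go, whether an amine or carboxylic acid on this aromatic ring, or a longer chain in its place, would shift the read-out remains open. So does the effect of any change to the shared core.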